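A Methoxy-for-Fluoro Step Toward Compound 4

The source may report more compounds than this note shows. Statements on the series, on what has been measured and on what is new or still open speak of the compounds shown alone.

Compound 1 `C=C(c1ccc(Cl)c(Cl)c1Cl)C1COC2(CCCCC2)OO1`: 1370 nM in a functional assay on A549 cells (Homo sapiens) for inhibition, read by MTT assay, with a stated time of 72 h; on this read-out higher numbers stand for weaker inhibition and lower numbers for stronger inhibition
Compound 2 `C=C(c1ccc(F)c(F)c1)C1COC2(CCCCC2)OO1`: 7880 nM
Compound 3 `C=C(c1cc(Cl)cc(Cl)c1OCc1ccccc1)C1COC(C)(C)OO1`: 58400 nM

Among these three numbers in this assay, compound 2 gives the second highest; compound 1 lies well below it and compound 3 well above it, both gaps beyond the scatter. Compound 4 `C=C(c1ccc(OC)c(F)c1)C1COC2(CCCCC2)OO1` is not yet measured. It differs from compound 2 in one place: methoxy in place of fluoro on an aromatic carbon. Within the data shown here, no measured pair shows this change, so its effect cannot be read from the data; compound 1 against compound 2 involves other halogens at other positions and shows only that ring substitution can move the read-out well beyond the scatter. The step from compound 2 to compound 4 is therefore expected to be modest, a 1.3-fold lower number from compound 2 to compound 4 (0.12 log units; within the scatter), with either direction possible. Compound 4 is estimated at 6000 nM, within 1500 nM to 25000 nM.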

Compound 4, half-maximal inhibitory concentration: 6530 nM
Estimate against measurement, compound 4: 1.1-fold (0.04 log units) below; the measured number falls inside the stated range.
By their numbers in this assay, from the lowest: compound 1; then compounds 4 and 2 (each within the scatter of the next); then compound 3.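

In this assay, this change at this position can now be read directly: a 1.2-fold lower number from compound 2 to compound 4 (0.08 log units; within the scatter). Among these compounds, on this aromatic carbon, ortho to a fluoro group and para to a large group, methoxy and fluoro therefore cannot be told apart, a finding that the earlier compounds could not give. Nothing at hand offers a reason for this result.

On these data alone, it remains open whether an amine, a carboxylic acid or a longer chain such as ethoxy would also stay within the scatter here. Also open, as far as these compounds go, is whether methoxy would read the same in place of the other fluoro group.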